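Swapping the benzyl aryl group in a quinoline diamine series

A few compounds are considered here, and "the series" means these few. Any claim that something is new, unique, unknown or untested is made for them only; others in the source may bear on it.

In a physicochemical assay for acid dissociation, compound 3 `COc1ccccc1Oc1ccc2c(NCCCNCc3cccc(OC)c3O)ccnc2c1` gives 9.28, the same at the digits shown as compound 2 `COc1ccc(F)cc1CNCCCNc1ccnc2cc(Oc3ccc(C(C)(C)C)cc3)ccc12` with 9.28, and within the scatter of compound 1 `CCC(CC)c1ccc2c(NCCCNCc3cc(F)ccc3OC)ccnc2c1` with 9.47. Among the measured compounds shown here, the only measured step, a number 0.19 log units lower from compound 1 to compound 2 (within the scatter), changes a distant aryl position and stays within the scatter. Compound 4 `COc1ccc(F)cc1CNCCCNc1ccnc2cc(Oc3ccccc3OC)ccc12` differs from compound 3 by 5-fluoro-2-methoxyphenyl in place of 2-hydroxy-3-methoxyphenyl on a saturated chain carbon bound to an amine nitrogen. For the measured compounds named here, no measured step covers this exact exchange, yet compound 2 already carries the entering benzyl group and sits level with compound 3, so no shift beyond the scatter is expected. Compound 4 is therefore estimated at 9.3, between 8.95 and 9.65, a step of a number 0.02 log units higher from compound 3 to compound 4 (within the scatter) expected to be negligible.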

Compound 4, acid dissociation constant: 9.28
Estimate against measurement, compound 4: 0.02 log units above; the measured number falls inside the stated range.
By their numbers in this assay, from the lowest: compounds 2, 3, 4 and 1 (each within the scatter of the next).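

In this assay, the first change read at the saturated chain carbon bound to an amine nitrogen, 5-fluoro-2-methoxyphenyl for 2-hydroxy-3-methoxyphenyl, gives (no change at the digits printed from compound 3 to compound 4 (within the scatter)) even though the hydrogen-bond donor of the leaving group is gone. The second and third steps, at the far aryl end, stay just as small (no change at the digits printed from compound 2 to compound 4 (within the scatter); a number 0.19 log units lower from compound 1 to compound 4 (within the scatter)), so all four numbers sit within the scatter. No supporting measurement bears on this result. Still open, from the compounds shown here alone, is whether a carboxylic acid or a dimethylamino group on this benzyl ring would shift the number beyond the scatter.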